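Trifluoromethyl in Place of Methoxy: Expectation for Compound 4

The source may hold more compounds than are shown below. What is called first, only, known or untested is meant among the compounds shown, and "the series" means these compounds.

Three compounds of one shared core have been measured in a functional assay on HeLa cells (Homo sapiens) for inhibition, read by sulforhodamine B assay, with a stated time of 48 h; a higher number here means a weaker inhibitor of growth, a lower number a stronger inhibitor of growth:

Compound 1, `COC(=O)[C@@]1(C)CCC=C2[C@@H]1CC[C@@H](C)[C@]2(C)Cc1c[nH]c2ccc(C(F)(F)F)cc12`: 11000 nM
Compound 2, `COC(=O)[C@@]1(C)CCC=C2[C@@H]1CC[C@@H](C)[C@]2(C)Cc1c(C)[nH]c2ccccc12`: 11000 nM
Compound 3, `COC(=O)[C@@]1(C)CCC=C2[C@@H]1CC[C@@H](C)[C@]2(C)Cc1c(C)[nH]c2ccc(OC)cc12`: 12000 nM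

Compound 3 stands within the scatter of both companions: its gap to compound 1 and its gap to compound 2 are each too small to count, so the three numbers cannot be told apart. Going by the values given here, the only single-place step among them runs from compound 2 to compound 3, a 1.1-fold higher number from compound 2 to compound 3 (0.04 log units; within the scatter), which shows that adding methoxy at that aromatic carbon left the number where it was.

Compound 4, `COC(=O)[C@@]1(C)CCC=C2[C@@H]1CC[C@@H](C)[C@]2(C)Cc1c(C)[nH]c2ccc(C(F)(F)F)cc12`, has not been measured in this assay. It differs from compound 3 in one place: trifluoromethyl in place of methoxy on an aromatic carbon. Among the compounds with values here, no measured step covers exactly this exchange, but two observations bear on it. The step from compound 2 to compound 3 was flat, and compound 1, which carries trifluoromethyl at the same place but lacks the methyl on the five-membered ring, gives 11000 nM, within the scatter of compound 3. Nothing here points to a change beyond the scatter.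

Compound 4 is therefore expected to give about 11000 nM in this assay, in the range from 5500 nM to 22000 nM. The expected step is a 1.1-fold lower number from compound 3 to compound 4 (0.04 log units; within the scatter), that is, none beyond the scatter.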

Compound 4, concentration for 50% growth inhibition: 12000 nM
Estimate against measurement, compound 4: 1.1-fold (0.04 log units) below; the range from low to high includes it.
By their numbers in this assay, from the lowest: compounds 1, 2, 3 and 4 (each within the scatter of the next).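

In this assay, the exchange at this aromatic carbon, where methoxy with 1 hydrogen-bond acceptor gives way to trifluoromethyl with 0 hydrogen-bond acceptors, produced no change at the digits printed from compound 3 to compound 4 (within the scatter). Trifluoromethyl in place of hydrogen at the same carbon gave a 1.1-fold higher number from compound 2 to compound 4 (0.04 log units; within the scatter), and with a 1.1-fold higher number from compound 2 to compound 3 (0.04 log units; within the scatter) for methoxy in place of hydrogen, the three groups tested at this place on the shared core cannot be told apart. Going by these compounds alone, the methyl in place of hydrogen, seen here for the first time as a single change with trifluoromethyl present, gave a 1.1-fold higher number from compound 1 to compound 4 (0.04 log units; within the scatter), so that change also left the number within the scatter.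

Nothing available accounts for this flat response, and the numbers alone offer no explanation of it. The compounds shown leave open whether an amine, a carboxylic acid or a longer chain on this aromatic carbon would shift the number beyond the scatter, and whether replacing the methyl ester of the shared core with a carboxylic acid would do so.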